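Sulfonyl amine in place of a bicyclic ether

This account rests on a few compounds, and the source may have more. Where it says the series, first, only, none or still open, it means among the compounds named here.

Compound 1 `Cc1cncc(CNC(=O)Nc2ccc(S(=O)(=O)N3CCOCC3)cc2)c1`: 40 nM
Compound 2 `O=C(NCc1cccnc1)Nc1ccc(S(=O)(=O)N2C3CCC2COC3)cc1`: 10 nM

Of the compounds shown here, two have so far been measured in an assay on isolated protein for inhibition of Nicotinamide phosphoribosyltransferase (Homo sapiens), read by spectrophotometry, with stated times of 15 min and 30 min; a lower number here means a stronger inhibitor, a higher number a weaker inhibitor. Compound 1 gives 40 nM. Compound 2 gives 10 nM, the lowest of the two numbers; its nearest neighbour is compound 1, whose number stands higher by a margin beyond the usual scatter. Within the data shown here, the two differ in more than one place, so no single structural step connects them.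

Compound 3 `N[C@H]1CC[C@H](NS(=O)(=O)c2ccc(NC(=O)NCc3cccnc3)cc2)CC1` has not yet been measured in this assay. It differs from compound 2 in one place: a group of 8 heavy atoms (6 carbon, 2 nitrogen; one six-membered non-aromatic ring of carbon only) in place of a group of 8 heavy atoms (6 carbon, 1 nitrogen, 1 oxygen; one five-membered non-aromatic ring with 1 hetero atom, one six-membered non-aromatic ring with 2 hetero atoms), on a sulfonyl sulfur. Among the measured compounds shown here, no measured pair shows a change of this kind, so there is nothing to calibrate against. The expectation is a moderate move upward, that is toward a weaker inhibitor, of the size given by a 3.0-fold higher number from compound 2 to compound 3 (0.48 log units; beyond the scatter), a step that goes beyond the scatter but remains modest. Compound 3 is therefore estimated at 30 nM in this assay, with a likely range from 8 nM to 150 nM.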

Compound 3, half-maximal inhibitory concentration: 4 nM
For compound 3 the middle estimate is 7.5-fold (0.88 log units) above the measured one; the whole stated range lies above it.
By their numbers in this assay, from the lowest: compound 3; then compound 2; then compound 1.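

At the sulfonyl sulfur whose other neighbour is aromatic carbon, in this assay, putting (4-aminocyclohexyl)amino in place of the group with a five-membered and a six-membered non-aromatic ring gives a 2.5-fold lower number from compound 2 to compound 3 (0.40 log units; beyond the scatter), a modest step that lies beyond the usual scatter. This is the first change in a single place among the compounds shown, and it reveals that this position accepts a carbon-only six-membered ring carrying 2 hydrogen-bond donors, where the departing group has none, with no loss in this measurement and a modest gain. No supporting measurement is available to say what lies behind this gain.

The compounds shown leave open whether the step belongs to the amine at the far end of the new group, to the carbon-only ring, or to the 2 defined stereocentres. A hydroxyl or a carboxylic acid in place of that amine, or an open alkyl chain in place of the cyclohexyl ring, lies outside these compounds, so the contribution of each part of the group remains unresolved.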